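A few compounds are considered here, and "the series" means these few. Any claim that something is new, unique, unknown or untested is made for them only; others in the source may bear on it.

Measured compounds:
compound 1 `N=C(Nc1cccc2ccccc12)N(c1ccccc1)c1cccc2ccccc12` gives 7930 nM
compound 2 `CN(C(=N)N(c1ccccc1)c1cccc2ccccc12)c1cccc2ccccc12` gives 11000 nM
compound 3 `CCc1cccc(NC(=N)Nc2cccc3ccccc23)c1` gives 54 nM

All three were tested in an assay on membranes from brain (Cavia porcellus) for binding affinity to Sigma non-opioid intracellular receptor 1 (Homo sapiens), read by radioligand binding; a lower number here means a stronger inhibitor, a higher number a weaker inhibitor. Compound 1 and compound 2 share a core in which one guanidine nitrogen carries two aromatic groups, and they differ only by methyl in place of hydrogen on a nitrogen on an aromatic ring. That change gave a 1.4-fold higher number from compound 1 to compound 2 (0.14 log units; within the scatter), so the two numbers cannot be told apart. Compound 3 has a different core, with a single aromatic group on each of its two outer guanidine nitrogens; how its core differs from that of compound 1 is not broken down here. What the values show is that compound 3 gives a far lower number than either compound 1 or compound 2, and its steps to both are beyond the scatter.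

Compound 4 `CCc1cccc(NC(=N)N(C)c2cccc3ccccc23)c1` has not yet been measured. It differs from compound 3 by methyl in place of hydrogen on a nitrogen on an aromatic ring. Going by the values given here, this is the same kind of change as the one from compound 1 to compound 2, and the surroundings of the place read the same in both cases. Among the compounds with values here, the only evidence for what a methyl on this nitrogen does comes from that one pair, where the step was within the scatter. Carrying that over, the expected step from compound 3 to compound 4 in this assay is a 2.0-fold higher number from compound 3 to compound 4 (0.31 log units; beyond the scatter), with some allowance for the cores being different. Compound 4 is therefore estimated at 110 nM, within a range from 30 nM to 450 nM.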

Compound 4, half-maximal inhibitory concentration: 1000 nM
Beside the measured number, compound 4's estimate is 9.1-fold (0.96 log units) below it; the measured number lies above the stated range.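

In this assay the new step is a 19-fold higher number from compound 3 to compound 4 (1.27 log units; beyond the scatter), which is large and means weaker binding once the methyl is in place. This change therefore does not move the number by one fixed amount wherever it is made, and its size differs markedly between these two cores: the same change on two cores in this assay, a 1.4-fold higher number (0.14 log units; within the scatter) from compound 1 to compound 2 and a 19-fold higher number (1.27 log units; beyond the scatter) from compound 3 to compound 4, 13-fold (1.13 log units) apart, beyond the scatter of two such steps.
Going by these compounds alone, this shows that a step measured on the core of compound 1 cannot safely be transferred unchanged to the core of compound 3, but with only two pairs it does not show which difference between the cores matters, or what size of step a third core would give.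

The compounds shown leave open what happens on this same nitrogen when the entering group is something other than methyl, such as a propyl chain, a longer chain or a chain ending in an amine. They also leave open whether the large step seen with the ethyl-bearing core of compound 3 would recur on other cores that have a single aromatic group on each outer guanidine nitrogen, or whether it is special to this one.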